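Methyl on the Aryl Ring: Compound 3 to Compound 4

The source may hold more compounds than are shown below. What is called first, only, known or untested is meant among the compounds shown, and "the series" means these compounds.

Compound 1 `Cc1ccc(C2=NN(c3nc(-c4ccccc4)c(C#N)c(=O)n3C)C(c3ccc(F)cc3)C2)cc1`: 4620 nM
Compound 2 `COc1ccc(C2CC(c3ccccc3)=NN2c2nc(-c3ccc(Cl)cc3)c(C#N)c(=O)n2C)cc1`: 11000 nM
Compound 3 `Cn1c(N2N=C(c3ccccc3)CC2c2ccc(F)cc2)nc(-c2ccc(Cl)cc2)c(C#N)c1=O`: 13700 nM

In a functional assay on HT-29 cells (Homo sapiens) for antiproliferative activity, with a stated time of 72 h (on this read-out lower numbers stand for stronger inhibition and higher numbers for weaker inhibition), compound 3 gives 13700 nM, separated from compound 1 beyond the scatter, while compound 2 lies within the scatter of it. Compound 4 `Cc1ccc(C2=NN(c3nc(-c4ccc(Cl)cc4)c(C#N)c(=O)n3C)C(c3ccc(F)cc3)C2)cc1` differs from compound 3 by methyl in place of hydrogen on an aromatic carbon. Within the data shown here, the only measured step, a 1.2-fold higher number from compound 2 to compound 3 (0.10 log units; within the scatter), concerns a different ring and does not isolate a methyl. Compound 1, which carries the same methyl but lacks the chloro, reads 4620 nM, so a modest move toward lower numbers seems plausible, though unsupported by any single-change step. Compound 4 is therefore expected near 8000 nM, between 3000 nM and 25000 nM, an estimated step of a 1.7-fold lower number from compound 3 to compound 4 (0.23 log units; within the scatter).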

Compound 4, half-maximal inhibitory concentration: 10500 nM
Compound 4: the middle estimate sits 1.3-fold (0.12 log units) below what was measured, within the range that was stated.
By their numbers in this assay, from the lowest: compound 1; then compounds 4, 2 and 3 (each within the scatter of the next).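

In this assay, methyl in place of hydrogen on this aromatic carbon gives a 1.3-fold lower number from compound 3 to compound 4 (0.12 log units; within the scatter), so adding the methyl to the phenyl ring leaves the read-out within the scatter. Among these compounds, with the methyl in place, adding the chloro gives a 2.3-fold higher number from compound 1 to compound 4 (0.36 log units; beyond the scatter), a modest step and the first single change here that lies beyond the scatter. No available evidence accounts for either step. The compounds shown leave open how an ethyl, an amine or a carboxylic acid would read in the methyl's place. They also leave open whether the chloro step holds when that ring carries no methyl.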